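Thioester variant of compound 1: lipophilicity outlook

A few compounds are considered here, and "the series" means these few. Any claim that something is new, unique, unknown or untested is made for them only; others in the source may bear on it.

Compound 1 `CCOC(=O)/C=C(C)/C=C/CC(C)CCCC(C)(C)OC` stands highest of the three measured compounds in a physicochemical assay for lipophilicity (a higher number here means a more lipophilic compound, a lower number a more polar compound), giving 5.54. Compound 2 `CCOC(=O)/C=C(C)/C=C/CC(C)CCC(O)C(C)C` gives 4.65 and compound 3 `CCOC(=O)/C=C(C)/C=C/CC(C)CCC1OC1(C)C` gives 4.76. The steps of a number 0.89 log units lower from compound 1 to compound 2 (beyond the scatter) and a number 0.78 log units lower from compound 1 to compound 3 (beyond the scatter) both alter the far end of the chain, and a number 0.11 log units higher from compound 2 to compound 3 (within the scatter). The new compound 4 `C=CCSC(=O)/C=C(C)/C=C/CC(C)CCCC(C)(C)OC` differs from compound 1 at the other end of the molecule: allylsulfanyl in place of ethoxy on a carbonyl carbon. Among the measured compounds shown here, no measured step touches the carbonyl carbon, so none of them calibrates this change; the expectation rests on the counted difference alone, with sulfur entering for oxygen and one more carbon in the chain. For compound 4 a rise beyond the scatter is expected, a number 0.86 log units higher from compound 1 to compound 4 (beyond the scatter). The estimate for compound 4 in this assay is 6.4, between 5.9 and 6.9.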

Compound 4, partition coefficient: 6.77
The estimate for compound 4 lay 0.37 log units below the measured number; measured number inside the range.
By their numbers in this assay, from the lowest: compounds 2 and 3 (each within the scatter of the next); then compound 1; then compound 4.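

The carbonyl carbon proves to be a position where the number in this assay responds strongly: allylsulfanyl in place of ethoxy gives a number 1.23 log units higher from compound 1 to compound 4 (beyond the scatter) and thus raises it, whereas the far-end changes lower it, with a number 0.89 log units lower from compound 1 to compound 2 (beyond the scatter) and a number 0.78 log units lower from compound 1 to compound 3 (beyond the scatter) as the measured steps. Nothing shown accounts for the size of this rise.

Going by these compounds, how much of the step belongs to sulfur and how much to the allyl part remains open; ethylsulfanyl or allyloxy on the same carbonyl carbon would separate the two. On these data alone, whether allylsulfanyl gives a similar step on compound 2 or compound 3 is also open.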